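HDAC8 hydroxamates: acyl-to-alkyl swap at the ring amine

The source may report more compounds than this note shows. Statements on the series, on what has been measured and on what is new or still open speak of the compounds shown alone.

Measured compounds:
- Compound 1 `COc1ccc(NC(=O)[C@@H]2Cc3ccc(OCC(=O)NO)cc3CN2C(=O)CNC(=O)OC(C)(C)C)cc1` gives 514 nM
- Compound 2 `COc1ccc(NC(=O)[C@@H]2Cc3ccc(OCC(=O)NO)cc3CN2C(=O)[C@@H]2CCCN2C(=O)OC(C)(C)C)cc1` gives 212 nM
- Compound 3 `COc1ccc(NC(=O)[C@@H]2Cc3ccc(OCC(=O)NO)cc3CN2C(=O)CCCc2ccccc2)cc1` gives 114 nM

In an assay on isolated protein for inhibition of histone deacetylase 8 (Homo sapiens), read by fluorescence, with a stated time of 30 min (a higher number here means a weaker inhibitor, a lower number a stronger inhibitor), compound 3 holds the lowest number of the three; its gap to compound 2 lies within the scatter, while the step of a 4.5-fold lower number from compound 1 to compound 3 (0.65 log units; beyond the scatter) lies beyond it. Compound 4 `COc1ccc(NC(=O)[C@@H]2Cc3ccc(OCC(=O)NO)cc3CN2CCCc2ccccc2)cc1` is compound 3 with 3-phenylpropyl in place of (3-phenylpropyl)carbonyl on an amine nitrogen in a ring. The measured steps of a 2.4-fold lower number from compound 1 to compound 2 (0.38 log units; beyond the scatter) and a 1.9-fold lower number from compound 2 to compound 3 (0.27 log units; within the scatter) all vary the group on the carbonyl and keep the carbonyl itself, so none bears directly on its removal. For the measured compounds named here, no step in this assay informs the change. A modest shift in either direction is expected, and compound 4 is estimated at 200 nM (range 60 nM to 700 nM), which means an expected step of a 1.8-fold higher number from compound 3 to compound 4 (0.24 log units; within the scatter).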

Compound 4, half-maximal inhibitory concentration: 1720 nM
For compound 4 the middle estimate is 8.6-fold (0.93 log units) below the measured one; the whole stated range lies below it.
By their numbers in this assay, from the lowest: compounds 3 and 2 (each within the scatter of the next); then compound 1; then compound 4.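

In this assay the step of a 15-fold higher number from compound 3 to compound 4 (1.18 log units; beyond the scatter) is the largest in the series, and it comes from removing the carbonyl on the ring amine nitrogen while keeping the phenyl-ended chain. The step of a 3.3-fold higher number from compound 1 to compound 4 (0.52 log units; beyond the scatter) puts the alkyl compound behind even the least active acylated compound. At this position, the presence of the carbonyl therefore counts for more than the changes made to the group on it.

No evidence on the cause of this loss is available. As far as these compounds go, whether a sulfonyl group or a urea carbonyl could stand in for the carbonyl remains open.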